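This account rests on a few compounds, and the source may have more. Where it says the series, first, only, none or still open, it means among the compounds named here.

Notes on the series. Compound 3 `CC(=O)OCCOCN1c2ccccc2C(=O)N(Cc2ccccc2)S1(=O)=O` stands beside compound 1 `O=C1c2ccccc2N(Cc2ccccc2)S(=O)(=O)N1COCc1ccccc1` as one of the two numbered results in a functional assay on CCRF-CEM cells (Homo sapiens) for cytotoxicity; on this read-out lower numbers stand for higher toxicity in this test and higher numbers for lower toxicity in this test: compound 3 gives 103 ug/mL and compound 1 gives 100 ug/mL, a pair that lies within the scatter of repeated runs, so no order is read between them. Compound 2 `O=C1c2ccccc2NS(=O)(=O)N1COCCO` in this assay gives only a limit, > 200 ug/mL, not a number. Compound 4 `O=C1c2ccccc2N(COCc2ccccc2)S(=O)(=O)N1Cc1ccccc1` is not yet measured. It differs from compound 3 by phenyl in place of acetoxymethyl on a saturated chain carbon bound to an oxygen on a saturated carbon. Within the data shown here, no step between measured compounds is available to calibrate this change; what is known is that compound 1, carrying the same two groups on the shared core, gives 100 ug/mL and sits close to compound 3. The expectation in this assay is therefore a 1.0-fold lower number from compound 3 to compound 4 (0.01 log units; within the scatter), nothing beyond the scatter. Compound 4 is estimated at 100 ug/mL, between 50 ug/mL and 200 ug/mL.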

Compound 4, half-maximal cytotoxic concentration: 25 ug/mL
Beside the measured number, compound 4's estimate is 4.0-fold (0.60 log units) above it; measured number below the stated range.
By their numbers in this assay, from the lowest: compound 4; then compounds 1 and 3 (each within the scatter of the next). At a limit, above all of these: compound 2.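

In this assay this place now has its first readable change, with phenyl in place of acetoxymethyl giving a 4.1-fold lower number from compound 3 to compound 4 (0.61 log units; beyond the scatter) and thus higher toxicity in this test. The swap of (2-acetoxyethoxy)methyl for (benzyloxy)methyl is therefore not silent on this core, though it rests on one pair. Nothing measured here accounts for the step.

From the compounds shown here alone, whether the ring itself or the loss of the acetoxy ending carries the step stays open. Also open, going by these compounds, is how an amine, a carboxylic acid or a longer chain at this place would read.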